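Swapping the alkyne cap: pentyl to tert-butyl

A few compounds are considered here, and "the series" means these few. Any claim that something is new, unique, unknown or untested is made for them only; others in the source may bear on it.

Measured so far:
Compound 1, `CC(=O)OCC(CCn1cc(C#CC2CC2)c(=O)n(C(=O)c2ccccc2)c1=O)COC(C)=O`, gives > 100000 nM in this assay.
Compound 2, `CCCCCC#Cc1cn(CCC(COC(C)=O)COC(C)=O)c(=O)n(C(=O)c2ccccc2)c1=O`, gives 53700 nM in this assay.

Going by the values given here, in a functional assay on HeLa cells (Homo sapiens) for antiproliferative activity, read by MTT assay, with a stated time of 72 h (a higher number here means a weaker inhibitor, a lower number a stronger inhibitor), compound 2 is the only compound with a number; compound 1 sits at a limit, > 100000 nM, and that value is a limit rather than a measurement. Among the compounds with values here, the single measured step, an at least 1.8-fold lower number from compound 1 to compound 2 (0.27 log units; that floor lies within the scatter), rests on (the limit of > 100000 nM in this assay, at which 1 of the 2 values shown sits), so its true size is unknown beyond its floor.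

Compound 3, `CC(=O)OCC(CCn1cc(C#CC(C)(C)C)c(=O)n(C(=O)c2ccccc2)c1=O)COC(C)=O`, differs from compound 2 only as follows: tert-butyl in place of pentyl on a triple-bonded carbon. Within the data shown here, the one measured step at this position shows that a change of the alkyne cap can move the number, but only a floor is known. A branched cap returning toward weaker inhibition seems plausible, so compound 3 is expected to show a rise, estimated as a 1.7-fold higher number from compound 2 to compound 3 (0.22 log units; within the scatter). The estimate for compound 3 is 90000 nM, ranging from 35000 nM to 250000 nM.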

Compound 3, half-maximal inhibitory concentration: 71500 nM
Beside the measured number, compound 3's estimate is 1.3-fold (0.10 log units) above it; low and high end bracket the measured number.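

In this assay the change from a pentyl cap to a tert-butyl cap gives a 1.3-fold higher number from compound 2 to compound 3 (0.12 log units; within the scatter) and so, between this straight chain and this branched one, no difference can be claimed at this triple-bonded carbon. The change from cyclopropyl to tert-butyl reads an at least 1.3-fold lower number from compound 1 to compound 3 (0.14 log units; that floor lies within the scatter) and sets no firm order among the three caps. Compound 1 gives > 100000 nM and this is a limit, not a number, so that step is only a floor: the limit of > 100000 nM in this assay, at which 1 of the 3 values shown sits.

All three caps are built from carbon and hydrogen alone, so the compounds shown leave open how this position responds to a cap carrying an amine or a hydroxyl group, or to a longer chain such as octyl. Going by these compounds, whether any such cap would bring the number far below those of compound 2 and compound 3 also stays open.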